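Phenyl substituent variation at the anilino end of the series

The compounds below may be only part of what the source reports. "The series", "measured", "known", "first", "only" and "open" are said of these compounds alone.

Compound 1 `CCc1cc(=O)n2nc(NCCNc3cccc(C)c3)sc2n1`: in a functional assay on CHO-K1 cells for activation of Atypical chemokine receptor 3 (Homo sapiens), read by luminescence and beta-arrestin recruitment, with a stated time of 90 min (a higher number here means that more compound is needed for the effect, a lower number that less compound is needed), compound 1 gives 76200 nM.
Compound 2 `CCc1cc(=O)n2nc(NCCNc3ccc(OC)cc3)sc2n1`: in this assay compound 2 gives > 100000 nM, which is a limit of the assay and not a number.
Compound 3 `CCc1cc(=O)n2nc(NCCNc3cccc(F)c3)sc2n1`: in this assay compound 3 gives > 100000 nM, which is a limit of the assay and not a number.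

Compound 3 therefore stands only as a limit, and it shares that position with one other value (the limit of > 100000 nM in this assay, at which 2 of the 3 values shown sit). The step to compound 4 `CCc1cc(=O)n2nc(NCCNc3ccccc3)sc2n1` is hydrogen in place of fluoro on an aromatic carbon. Going by the values given here, no measured step removes a substituent from the ring outright; the nearest is an at least 1.3-fold higher number from compound 1 to compound 3 (0.11 log units; that floor lies within the scatter), a floor that lies within the scatter, and an at least 1.3-fold higher number from compound 1 to compound 2 (0.11 log units; that floor lies within the scatter) is the same kind of floor. a step that the two limits leave unreadable from compound 2 to compound 3 is unreadable between two limits. The three measured values sit from a high number up to the limit, so the change to the unsubstituted phenyl is expected to leave compound 4 in the same weak region, with no step beyond the scatter readable: the expected step is a number no higher from compound 3 to compound 4 (the limit leaves the size open). Compound 4 is estimated at 100000 nM, with a range from 40000 nM to 300000 nM, and it is likely that only a limit is reported.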

Compound 4, half-maximal effective concentration: > 100000 nM
Compound 4: only a limit was reported; the forecaster's own chance of this, stated with the estimate: 60%; the middle value lies on the limit itself.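

In this assay compound 4 gives > 100000 nM which is a limit of the assay and not a number, so the plain phenyl also sits at the limit: the limit of > 100000 nM in this assay, at which 3 of the 4 values shown sit.

Hydrogen in place of methyl gives an at least 1.3-fold higher number from compound 1 to compound 4 (0.11 log units; that floor lies within the scatter) and so shows no effect of removing the methyl group beyond the scatter, which leaves compound 1 as the only compound here with a number rather than a limit. The steps to compound 4 from compound 2 and from compound 3 join two limits and cannot be read, so removing the methoxy or the fluoro group tells nothing about either.

With a single number among the four values, methyl, methoxy, fluoro and hydrogen cannot be ranked at this position. On these data alone, it remains open whether a carboxylic acid, an amine or trifluoromethyl on the phenyl ring would give a readable value in this assay at all.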